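This account rests on a few compounds, and the source may have more. Where it says the series, first, only, none or still open, it means among the compounds named here.

Working notes on the series. Compound 1 `O=C(Nc1cccc(CNc2ncnc3ccccc23)c1)Nc1ccccc1Cl` and compound 2 `O=C(Nc1ccc([N+](=O)[O-])cc1)Nc1cccc(CNc2ncnc3ccccc23)c1` share the same core and differ only in the aryl group on the amide-type nitrogen. In a functional assay on A549 cells (Homo sapiens) for antiproliferative activity, read by MTT assay (a higher number here means a weaker inhibitor, a lower number a stronger inhibitor), compound 1 gives 18000 nM. For compound 2 the reading in this assay is a limit, > 50000 nM, not a number (the limit of > 50000 nM in this assay, at which 1 of the 2 values shown sits). The step of an at least 2.7-fold higher number from compound 1 to compound 2 (0.44 log units; beyond the scatter) is accordingly only a lower bound on the loss. Compound 2 thus stands at the weak end of what has been measured so far, with no number of its own.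

Compound 3 `O=C(Nc1cccc(CNc2ncnc3ccccc23)c1)Nc1cccc(C(F)(F)F)c1` is the next member; its change from compound 2 is 3-(trifluoromethyl)phenyl in place of 4-nitrophenyl on an amide-type nitrogen. Within the data shown here, the one measured step that bears on this position, an at least 2.7-fold higher number from compound 1 to compound 2 (0.44 log units; beyond the scatter), shows that the aryl group on this nitrogen can shift the number beyond the scatter. Among the measured compounds shown here, no measured pair carries the 3-(trifluoromethyl)phenyl group, so the direction rests on compound 2 already sitting at the limit: a move back to a measurable number is the more likely outcome, of modest size. Compound 3 is expected to give 25000 nM in this assay, with a range from 8000 nM to 70000 nM. The estimated step is an at least 2.0-fold lower number from compound 2 to compound 3 (0.30 log units; that floor lies within the scatter).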

Compound 3, half-maximal inhibitory concentration: 44200 nM
Estimate against measurement, compound 3: 1.8-fold (0.25 log units) below, within the range that was stated.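

In this assay, the 3-(trifluoromethyl)phenyl group gives a second reading with a real number on this amide-type nitrogen, and a 2.5-fold higher number from compound 1 to compound 3 (0.39 log units; beyond the scatter) shows that 2-chlorophenyl is not interchangeable with this group either; unlike the earlier bound, this step has a measured size. Against the 4-nitrophenyl group, the change reads only as an at least 1.1-fold lower number from compound 2 to compound 3 (0.05 log units; that floor lies within the scatter), so the data set no order between compound 2 and compound 3, and the two groups cannot be separated here. The reading for compound 2 remains a limit, not a number: the limit of > 50000 nM in this assay, at which 1 of the 3 values shown sits.

Among the three aryl groups shown, 2-chlorophenyl gives the lowest number, but with so few groups this cannot be separated into an effect of the chlorine itself or of where it sits on the ring. Still open, as far as these compounds go, is whether an unsubstituted phenyl, a phenyl carrying an amine or a carboxylic acid, or a simple alkyl chain on this nitrogen would bring the number below that of compound 1, and how changes elsewhere on the shared core would read.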